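The source may hold more compounds than are shown below. What is called first, only, known or untested is meant among the compounds shown, and "the series" means these compounds.

Series notes. The shared core carries a urea-linked aryl on one side and a 4-chloro-3-hydroxyphenyl or 4-chloro-3-methoxyphenyl on the other. In a functional assay on A549 cells (Homo sapiens) for inhibition, read by sulforhodamine B assay, with a stated time of 48 h (a higher number here means a weaker inhibitor of growth, a lower number a stronger inhibitor of growth), compound 2 `COc1cc(-c2nn(-c3cccc(NC(=O)Nc4ccc(Cl)c(Cl)c4)c3)cc2-c2ccncc2)ccc1Cl` gives 745 nM; compound 1 `O=C(Nc1cccc(-n2cc(-c3ccncc3)c(-c3ccc(Cl)c(O)c3)n2)c1)Nc1cccc(C(F)(F)F)c1` gives 1370 nM in this assay, and the two numbers lie within the scatter of each other, so no order between them is claimed. Compound 3 `O=C(Nc1cccc(-n2cc(-c3ccncc3)c(-c3ccc(Cl)c(O)c3)n2)c1)Nc1ccc(Cl)c(Cl)c1` keeps the dichlorophenyl urea of compound 2 and differs only by hydrogen in place of methyl on an oxygen on an aromatic ring. Among the measured compounds shown here, no measured step of this kind is available. The step from compound 2 to compound 3 in this assay is expected to be small, a 1.1-fold higher number from compound 2 to compound 3 (0.03 log units; within the scatter), with no direction beyond the scatter. Compound 3 is therefore estimated at 800 nM, with a range from 350 nM to 1800 nM.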

Compound 3, concentration for 50% growth inhibition: 1010 nM
For compound 3 the middle estimate is 1.3-fold (0.10 log units) below the measured one; the measured number falls inside the stated range.
By their numbers in this assay, from the lowest: compounds 2, 3 and 1 (each within the scatter of the next).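

In this assay, methoxy to hydroxy on the 4-chloro-3-methoxyphenyl group, with the 3,4-dichlorophenyl urea held fixed, gives a 1.4-fold higher number from compound 2 to compound 3 (0.13 log units; within the scatter) and so does not separate the two compounds. With the 4-chloro-3-hydroxyphenyl group held fixed, 3,4-dichlorophenyl in place of 3-(trifluoromethyl)phenyl on the amide-type nitrogen gives a 1.4-fold lower number from compound 1 to compound 3 (0.13 log units; within the scatter) and likewise separates nothing. No independent data bear on these results.

Open, going by these compounds, is whether ethoxy, a longer chain on that oxygen, or an amine in place of hydroxy would give a step beyond the scatter.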